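A Reshaped Sulfonamide Side Chain on a Shared Core

The source may hold more compounds than are shown below. What is called first, only, known or untested is meant among the compounds shown, and "the series" means these compounds.

In a functional assay on M14 cells (Homo sapiens) for inhibition, read by sulforhodamine B assay, with a stated time of 48 h (on this read-out lower numbers stand for stronger inhibition and higher numbers for weaker inhibition), compound 1 `CN1CCCN(CCNc2nccc(-c3c(-c4cccc(O)c4)nc4sccn34)n2)S1(=O)=O` gives 174 nM, while compound 2 `O=S(=O)(NCCCNc1nccc(-c2c(-c3cccc(O)c3)nc3sccn23)n1)c1cccc(F)c1` gives 2540 nM, the higher of the two numbers and so the weaker inhibition. Compound 3 `O=S(=O)(NCCNc1nccc(-c2c(-c3cccc(O)c3)nc3sccn23)n1)c1ccc(F)cc1` has not yet been measured. It differs from compound 2 on a saturated chain carbon, two bonds along the chain from a nitrogen on an aromatic ring: ((4-fluorophenyl)sulfonyl)amino in place of (((3-fluorophenyl)sulfonyl)amino)methyl on a saturated chain carbon, two bonds along the chain from a nitrogen on an aromatic ring. Among the measured compounds shown here, only one measured step touches this place, a 15-fold higher number from compound 1 to compound 2 (1.16 log units; beyond the scatter), which is large and beyond the scatter. That step exchanged two very different groups, whereas the two groups here are close in make-up, so it shows that numbers can move far at this place but does not set the size of this change. In this assay, a small move to a lower number is expected, possibly none beyond the scatter. The expected change is a 1.4-fold lower number from compound 2 to compound 3 (0.15 log units; within the scatter). The estimate for compound 3 is 1800 nM, with an expected range of 500 nM to 6000 nM.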

Compound 3, half-maximal inhibitory concentration: 567 nM
Beside the measured number, compound 3's estimate is 3.2-fold (0.50 log units) above it, within the range that was stated.
By their numbers in this assay, from the lowest: compound 1; then compound 3; then compound 2.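

Two groups close in make-up can still separate clearly on this saturated chain carbon: in this assay the swap gives a 4.5-fold lower number from compound 2 to compound 3 (0.65 log units; beyond the scatter). The large earlier step therefore did not need a very different group, since ((4-fluorophenyl)sulfonyl)amino in place of (((3-fluorophenyl)sulfonyl)amino)methyl already moves the number beyond the scatter. Even so, the better of the two fluorophenyl groups does not match the group with the six-membered non-aromatic ring, leaving a 3.3-fold higher number from compound 1 to compound 3 (0.51 log units; beyond the scatter), and nothing measured here gives a reason for either step.

This swap removes the methyl link and changes 3-fluorophenyl to 4-fluorophenyl together, so the compounds shown cannot tell which of the two changes carries the step. Also open, on these data alone, is how a phenylsulfonyl group without fluorine, or a carboxylic acid, would read at this place.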